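A Hydroxymethyl Added to an Amide Side Chain

The source may report more compounds than this note shows. Statements on the series, on what has been measured and on what is new or still open speak of the compounds shown alone.

Compound 1 `CCn1c(C(=O)N[C@@H](C)CO)ccc1C(CC)(CC)c1ccc(OCS(=O)(=O)c2ccccc2)c(C)c1` and compound 2 `CCn1c(C(=O)N[C@H](C)CO)ccc1C(CC)(CC)c1ccc(OCS(=O)(=O)c2ccccc2)c(C)c1` share one skeleton and differ only in how a single stereocentre is drawn. In a functional assay on MCF7 cells (Homo sapiens) for antiproliferative activity, read by MTT assay, with a stated time of 24 h (a higher number here means a weaker inhibitor, a lower number a stronger inhibitor), compound 1 gives 10800 nM, and compound 2 gives 10600 nM; the two sit together, and the step of a 1.0-fold lower number from compound 1 to compound 2 (0.01 log units; within the scatter) is no surprise because of the fact that compounds 1 and 2 differ only in the configuration as drawn. Compound 3 `CCn1c(C(=O)N[C@@H](CO)CCO)ccc1C(CC)(CC)c1ccc(OCS(=O)(=O)c2ccccc2)c(C)c1` carries the change (hydroxymethyl in place of hydrogen on a saturated chain carbon, two bonds along the chain from an amide-type nitrogen). Among the compounds with values here, the one measured step says nothing about adding a group, so the step of a 1.1-fold lower number from compound 2 to compound 3 (0.03 log units; within the scatter) is expected to stay within the scatter. Compound 3 is therefore estimated at 10000 nM, with a range from 4000 nM to 25000 nM.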

Compound 3, half-maximal inhibitory concentration: 27400 nM
Beside the measured number, compound 3's estimate is 2.7-fold (0.44 log units) below it; the whole stated range lies below it.
By their numbers in this assay, from the lowest: compounds 2 and 1 (each within the scatter of the next); then compound 3.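

Putting hydroxymethyl in place of hydrogen on this saturated chain carbon, two bonds along the chain from an amide-type nitrogen, does register in this assay, unlike the change of drawn configuration: the result is a 2.6-fold higher number from compound 2 to compound 3 (0.41 log units; beyond the scatter). Read as 3-hydroxy-1-(hydroxymethyl)propyl in place of 1-(hydroxymethyl)ethyl on the amide-type nitrogen, the change gives a step of similar size, a 2.5-fold higher number from compound 1 to compound 3 (0.40 log units; beyond the scatter). Nothing given here accounts for this rise.

On these data alone, how an amine or a carboxylic acid would read in place of the hydroxymethyl stays open. So does the effect of a longer chain, or of the opposite configuration at the carbon that carries the hydroxymethyl.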